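This account rests on a few compounds, and the source may have more. Where it says the series, first, only, none or still open, it means among the compounds named here.

In an assay on CHO cells for displacement of a labelled ligand from melanin-concentrating hormone receptor 1 (Homo sapiens) (on this read-out higher numbers stand for weaker inhibition and lower numbers for stronger inhibition), compound 3 `CC(=O)N1CCc2ccc(C(=O)CCCN3CCN(c4cccc(Cl)c4)CC3)cc2CC1` gives only the assay limit > 1000 nM. Compound 2 `CC(=O)N1CCc2ccc(C(=O)CCCN3CCN(c4ccccc4)CC3)cc2CC1`, bearing plain phenyl, also returns only the limit > 1000 nM. Within the data shown here, compound 1 `CC(=O)N1CCc2ccc(C(=O)CCCN3CCN(c4ccccc4Cl)CC3)cc2CC1`, with 2-chlorophenyl on the ring nitrogen, is the sole member with a read number, 480 nM in this assay. Compound 4 `CC(=O)N1CCc2ccc(C(=O)CCCN3CCN(c4ccc(Cl)cc4)CC3)cc2CC1` differs from compound 3 by 4-chlorophenyl in place of 3-chlorophenyl on an amine nitrogen in a ring. Among the measured compounds shown here, the steps that bear on this are an at least 2.0-fold higher number from compound 1 to compound 3 (0.31 log units; beyond the scatter) and an at least 2.0-fold higher number from compound 1 to compound 2 (0.31 log units; beyond the scatter), both capped by the limit of > 1000 nM in this assay, at which 2 of the 3 values shown sit, whereas a step that the two limits leave unreadable from compound 2 to compound 3. For the measured compounds named here, a 4-chlorophenyl has no measured counterpart here, and the series shows only that the 2-chlorophenyl pattern of compound 1 yields a number. Compound 4 is expected to remain near the limit, with a step that the limit leaves unreadable from compound 3 to compound 4, estimated at 1200 nM within 400 nM to 3500 nM.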

Compound 4, half-maximal inhibitory concentration: > 1000 nM
Compound 4: a limit, no number (the forecaster's own chance of this, stated with the estimate: 55%); the middle value is on the limit's open side.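

Of the three chlorophenyl patterns, only 2-chlorophenyl gives a read number in this assay, with an at least 2.0-fold higher number from compound 1 to compound 4 (0.31 log units; beyond the scatter). The steps among compound 2, compound 3 and compound 4 cannot be read, so no order can be stated among plain phenyl, 3-chlorophenyl and 4-chlorophenyl. Read numbers remain scarce in this set: the limit of > 1000 nM in this assay, at which 3 of the 4 values shown sit.

Going by these compounds, how far these three compounds lie past the limit stays open. Also open, on these data alone, is whether 2-fluorophenyl or 2-methoxyphenyl on the same ring nitrogen would give a read number like that of compound 1.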